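This account rests on a few compounds, and the source may have more. Where it says the series, first, only, none or still open, it means among the compounds named here.

Compound 1 `O=C(O)CC(Cc1nc2cc(C(F)(F)F)ccc2[nH]1)c1ccc(Cl)cc1` stands highest of the two numbers measured in an assay on isolated protein for inhibition of protein kinase C zeta type (Homo sapiens), read by 33P incorporation, tested at 200 uM (on this read-out higher numbers stand for a stronger effect at the one concentration tested and lower numbers for a weaker effect), where compound 1 gives 85%. Compound 2 `CCc1ccc2[nH]c(CC(CC(=O)O)c3ccc(Cl)cc3)nc2c1` gives 0% in this assay. Going by the values given here, the only measured step, ethyl in place of trifluoromethyl on an aromatic carbon, is a number 85 percentage points lower from compound 1 to compound 2 (beyond the scatter). Compound 3 `COC(=O)c1ccc2[nH]c(CC(CC(=O)O)c3ccc(Cl)cc3)nc2c1` alters the same group of compound 1: methoxycarbonyl in place of trifluoromethyl on an aromatic carbon. Since that one step removed the effect almost entirely, a large drop is expected here too, although a different group enters. Compound 3 is therefore expected to give about 30%, between 0% and 75%, a step of a number 55 percentage points lower from compound 1 to compound 3 (beyond the scatter).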

Compound 3, a percentage reported as inhibition, at one concentration (the size of the read-out at that concentration, not a potency): 0%
For compound 3 the middle estimate is 30 percentage points above the measured one, and the stated range covers the measured number.
By their numbers in this assay, from the lowest: compounds 2 and 3 (each within the scatter of the next); then compound 1.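

In this assay, methoxycarbonyl in place of trifluoromethyl gives a number 85 percentage points lower from compound 1 to compound 3 (beyond the scatter) and so matches the loss seen with ethyl: the collapse is not peculiar to ethyl, and among these three groups only trifluoromethyl keeps the effect. Going from ethyl to methoxycarbonyl gives no change at the digits printed from compound 2 to compound 3 (within the scatter) even though the group entering has hydrogen-bond acceptors, so this read-out does not separate the two. No measurement here explains why trifluoromethyl stands apart. As far as these compounds go, whether a nitrile or a single chlorine atom at this position would keep the effect remains open.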